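The compounds below may be only part of what the source reports. "The series", "measured", "known", "first", "only" and "open" are said of these compounds alone.

Working notes on the series. In a functional assay on A549 cells (Homo sapiens) for antiproliferative activity, read by sulforhodamine B assay, with a stated time of 72 h (a lower number here means a stronger inhibitor, a higher number a weaker inhibitor), compound 1 (`Cc1ccc(S(=O)(=O)Nc2cc(SCC(=O)N[C@@H](CC(C)C)B(O)O)c(O)c3ccccc23)cc1`) gives 8900 nM, compound 2 (`CC(C)C[C@H](NC(=O)CSc1cc(NS(=O)(=O)c2ccccc2)c2ccccc2c1O)B(O)O`) gives 5940 nM and compound 3 (`CC(C)C[C@H](NC(=O)CSc1cc(NS(=O)(=O)c2ccc(Cl)cc2)c2ccccc2c1O)B(O)O`) gives 6900 nM. Compound 3 therefore stands within the scatter of both other compounds, and the three numbers form a single group.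

The next change leads to compound 4 (`CC(C)C[C@H](NC(=O)CSc1cc(NS(=O)(=O)c2cccs2)c2ccccc2c1O)B(O)O`), with thiophen-2-yl in place of 4-chlorophenyl on a sulfonyl sulfur.

Among the compounds with values here, three measured steps bear on this change, each exchanging one substituent on an aromatic carbon: a 1.5-fold lower number from compound 1 to compound 2 (0.18 log units; within the scatter), a 1.3-fold lower number from compound 1 to compound 3 (0.11 log units; within the scatter) and a 1.2-fold higher number from compound 2 to compound 3 (0.07 log units; within the scatter). All three stay within the scatter, so hydrogen, methyl and chloro cannot be told apart in this assay on these data. Within the data shown here, none of them replaces the aromatic ring itself, so the exchange of a six-membered ring for a five-membered one has no direct precedent here, and the expectation carries extra uncertainty.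

Compound 4 is expected close to compound 3 at 6900 nM, with no step beyond the scatter and no preferred direction. The expected change is small, a 1.1-fold lower number from compound 3 to compound 4 (0.03 log units; within the scatter). The estimate for compound 4 is 6500 nM, with an expected range of 3000 nM to 13000 nM.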

Compound 4, half-maximal inhibitory concentration: 7540 nM
For compound 4 the middle estimate is 1.2-fold (0.06 log units) below the measured one; the range from low to high includes it.
By their numbers in this assay, from the lowest: compounds 2, 3, 4 and 1 (each within the scatter of the next).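

In this assay, within the data shown here, the exchange of the whole aromatic ring on the sulfonyl sulfur, which the earlier steps on aromatic carbon did not touch, reads a 1.1-fold higher number from compound 3 to compound 4 (0.04 log units; within the scatter) for thiophen-2-yl in place of 4-chlorophenyl, a 1.3-fold higher number from compound 2 to compound 4 (0.10 log units; within the scatter) for thiophen-2-yl in place of phenyl and a 1.2-fold lower number from compound 1 to compound 4 (0.07 log units; within the scatter) for thiophen-2-yl in place of 4-methylphenyl. A five-membered aromatic ring with one hetero atom therefore cannot be told apart from a six-membered aromatic ring of carbon only at this position, and the four compounds remain a single group with no order among them. Nothing available here bears on why this exchange leaves the number within the scatter.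

On these data alone, all four compounds carry an aromatic ring on the sulfonyl sulfur, so it stays open whether a non-aromatic group there, such as methyl, cyclohexyl or a longer alkyl chain, or an aromatic ring carrying an amine or a carboxylic acid, would give a step beyond the scatter. As far as these compounds go, the rest of the shared core is the same throughout, so the effect of a change elsewhere in the molecule also stays open.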